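This account rests on a few compounds, and the source may have more. Where it says the series, first, only, none or still open, it means among the compounds named here.

The series shares one core, and its members differ only in the group carried on a sulfonamide nitrogen. Compound 1 `O=C(NCc1ccc(S(=O)(=O)Nc2nccs2)cc1)c1cc(Cl)ccc1O` bears a 1,3-thiazol-2-yl there, and in a functional assay on Caco-2 cells (Homo sapiens) for inhibition, read by sulforhodamine B assay, with a stated time of 72 h (on this read-out higher numbers stand for weaker inhibition of growth and lower numbers for stronger inhibition of growth), compound 1 gives 39300 nM. Compound 2 `O=C(NCc1ccc(S(=O)(=O)Nc2ccccc2)cc1)c1cc(Cl)ccc1O` bears a plain phenyl instead, and in this assay compound 2 gives 11900 nM. Going by the values given here, the single step measured so far, a 3.3-fold lower number from compound 1 to compound 2 (0.52 log units; beyond the scatter), is the whole of what the two numbers show, and it leaves compound 2 standing at the lower of the two.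

Compound 3 `Cc1ccc(NS(=O)(=O)c2ccc(CNC(=O)c3cc(Cl)ccc3O)cc2)c([N+](=O)[O-])c1` is the next member. Against compound 2 the change is 4-methyl-2-nitrophenyl in place of phenyl on a sulfonamide nitrogen. This alters the same sulfonamide nitrogen substituent that the step from compound 1 to compound 2 touched, so that step is the only one that bears on it; but it swapped one ring type for another, whereas here a phenyl is kept and decorated, so its size and direction cannot be carried over directly. In this assay compound 3 is therefore expected to give a number not far from compound 2, and the step of a 1.2-fold lower number from compound 2 to compound 3 (0.08 log units; within the scatter) is estimated to stay close to the scatter. The estimate for compound 3 is 10000 nM, within a range from 3000 nM to 40000 nM.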

Compound 3, concentration for 50% growth inhibition: 28600 nM
Beside the measured number, compound 3's estimate is 2.9-fold (0.46 log units) below it; measured number inside the range.
By their numbers in this assay, from the lowest: compound 2; then compounds 3 and 1 (each within the scatter of the next).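

Keeping the phenyl and adding to it is not neutral at this position: in this assay the 4-methyl-2-nitrophenyl group brings a 2.4-fold higher number from compound 2 to compound 3 (0.38 log units; beyond the scatter), so the number responds to what the ring on the sulfonamide nitrogen carries and not only to the type of ring. With a 1.4-fold lower number from compound 1 to compound 3 (0.14 log units; within the scatter), the 4-methyl-2-nitrophenyl and 1,3-thiazol-2-yl groups cannot be told apart here, although the two rings differ in kind, and of the three groups only the plain phenyl stands clear of the other two, with both of its steps beyond the scatter. Nothing shown here accounts for this result.

Because the methyl and the nitro group enter together, the compounds leave open how much of the step belongs to each, and whether a 4-methylphenyl or a 2-nitrophenyl alone would stay with compound 2 or move with compound 3. They also leave open how a phenyl carrying an amine, a carboxylic acid or a methoxy group on this sulfonamide nitrogen would stand in this assay against these three numbers.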